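A few compounds are considered here, and "the series" means these few. Any claim that something is new, unique, unknown or untested is made for them only; others in the source may bear on it.

In a functional assay on MCF7 cells (Homo sapiens) for inhibition, read by sulforhodamine B assay (on this read-out lower numbers stand for stronger inhibition and higher numbers for weaker inhibition), compound 3 `COc1ccccc1NC1=CC(=O)c2c(nc3n2[C@H]2OC[C@@H](O)[C@H]2OC3)C1=O` gives 6580 nM, the highest of the two numbers shown. Compound 1 `O=C1C(Nc2cccc(Cl)c2)=CC(=O)c2c1nc1n2[C@H]2OC[C@@H](O)[C@H]2OC1` gives 2970 nM in this assay, the nearest number to compound 3. Compound 2 `O=C1C(N2CCCCC2)=CC(=O)c2c1nc1n2[C@H]2OC[C@@H](O)[C@H]2OC1` reaches only the limit of this assay, > 8000 nM. Compound 4 `O=C1C(Nc2ccccc2)=CC(=O)c2c1nc1n2[C@H]2OC[C@@H](O)[C@H]2OC1` differs from compound 3 by hydrogen in place of methoxy on an aromatic carbon. The measured step that bears on this is the exchange of the aryl group on the amine nitrogen, which gave a 2.2-fold higher number from compound 1 to compound 3 (0.35 log units; beyond the scatter); the step of an at least 2.6-fold higher number from compound 1 to compound 2 (0.43 log units; beyond the scatter) concerns a different replacement. Because a 2.2-fold higher number from compound 1 to compound 3 (0.35 log units; beyond the scatter) accompanied the move to 2-methoxyphenyl, a partial reversal is expected for compound 4, with a step of a 1.5-fold lower number from compound 3 to compound 4 (0.17 log units; within the scatter). Compound 4 is therefore expected to give 4500 nM, in the range 1500 nM to 12000 nM.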

Compound 4, half-maximal inhibitory concentration: > 4000 nM
Compound 4 was reported as a limit; the forecaster's own chance of this, stated with the estimate: 25%; the middle value does not contradict the limit.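

In this assay compound 4 stands only at a limit, > 4000 nM. Hydrogen in place of chloro on an aromatic carbon gave an at least 1.3-fold higher number from compound 1 to compound 4 (0.12 log units; that floor lies within the scatter), so even the floor of this step cannot be told from scatter. The steps to compound 4 from compound 3 and from compound 2 cannot be read.

From the compounds shown here alone, whether methoxy on this aromatic carbon gives a higher or a lower number than hydrogen therefore stays open. So does how a fluoro or a hydroxy group on that carbon would read.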